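A few compounds are considered here, and "the series" means these few. Any claim that something is new, unique, unknown or untested is made for them only; others in the source may bear on it.

In a functional assay on HepG2 cells (Homo sapiens) for cytotoxicity, read by MTT assay, with a stated time of 24 h (a lower number here means a stronger inhibitor, a higher number a weaker inhibitor), compound 1 `COc1cc(O)cc(/C=C/c2ccc(OC)c(O)c2OC)c1` gives > 100000 nM, which is a limit of the assay and not a number. Among the measured compounds shown here, compound 2 `COc1cc(O)cc(/C=C/c2ccc(O)c(OC)c2OC)c1` gives 37100 nM in this assay, the only actual number so far, so it can be ranked against no other measured value. Compound 3 `COc1cc(O)cc(/C=C/c2cccc(OC)c2OC)c1` differs from compound 2 at one place hydrogen in place of hydroxy on an aromatic carbon, ortho to a methoxy group, meta to a methoxy group and para to a large group. For the measured compounds named here, no measured step shows what this kind of change does, so the expectation is a loose one. A modest weakening, little beyond the scatter, is expected in this assay, and a 1.5-fold higher number from compound 2 to compound 3 (0.17 log units; within the scatter) is the estimated step. Compound 3 is estimated at 55000 nM, with an expected range from 20000 nM to 120000 nM.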

Compound 3, half-maximal inhibitory concentration: > 100000 nM
Compound 3 was reported as a limit (the forecaster's own chance of this, stated with the estimate: 35%); middle value at least 1.8-fold (0.25 log units) from the limit.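

With hydrogen in place of hydroxy on this aromatic carbon, ortho to a methoxy group, meta to a methoxy group and para to a large group, this assay shows an at least 2.6-fold higher number from compound 2 to compound 3 (0.43 log units; beyond the scatter). Among the compounds shown here, this is the first step measured at this position, and it shows that, between these two compounds, the hydroxy group goes with the only actual number in the set. The step is a lower bound and its full size cannot be read, because the result for compound 3 is a limit of the assay and not a number: the limit of > 100000 nM in this assay, at which 2 of the 3 values shown sit.

As far as these compounds go, whether an ethoxy group, a fluorine atom or an amine on this carbon would give a measurable number remains open. Also open, from the compounds shown here alone, is what the same change would do at the other hydroxy group of the shared core.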